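Swapping a bromophenyl amide for a chloropyridinyl amide

The source may hold more compounds than are shown below. What is called first, only, known or untested is meant among the compounds shown, and "the series" means these compounds.

Compound 3 `O=C(Nc1cccc(-c2oc3cc(-c4ccc(F)cc4)ccc3c(=O)c2O)c1)c1ccc(Br)cc1` is one of three close relatives that share a core and differ only in the group attached to the amide carbonyl. In a functional assay on HepG2 cells (Homo sapiens) for antiproliferative activity, read by CCK-8 assay, with a stated time of 72 h (a higher number here means a weaker inhibitor, a lower number a stronger inhibitor), compound 3 gives 13900 nM. Compound 2 `O=C(Nc1cccc(-c2oc3cc(-c4ccc(F)cc4)ccc3c(=O)c2O)c1)c1ccc(Cl)cc1` gives 11000 nM, and compound 1 `Cc1ccc(C(=O)Nc2cccc(-c3oc4cc(-c5ccc(F)cc5)ccc4c(=O)c3O)c2)cc1` gives 2320 nM. Compound 3 has the highest number of the three, but the gap to compound 2 is within the scatter, so the two cannot be told apart; both stand clearly apart from compound 1, with a 4.7-fold higher number from compound 1 to compound 2 (0.68 log units; beyond the scatter) and a 6.0-fold higher number from compound 1 to compound 3 (0.78 log units; beyond the scatter), while a 1.3-fold higher number from compound 2 to compound 3 (0.10 log units; within the scatter) is within the scatter.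

Compound 4 `O=C(Nc1cccc(-c2oc3cc(-c4ccc(F)cc4)ccc3c(=O)c2O)c1)c1ccc(Cl)nc1` is not yet measured. Its change from compound 3 is 6-chloropyridin-3-yl in place of 4-bromophenyl on a carbonyl carbon. Among the compounds with values here, no measured step covers a ring nitrogen entering at this place; the only steps known are halogen for methyl and bromo for chloro. Compound 4 is therefore expected to stay near compound 3, with an estimated step of a 1.2-fold lower number from compound 3 to compound 4 (0.06 log units; within the scatter), and an estimated value of 12000 nM, within a range from 4000 nM to 35000 nM.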

Compound 4, half-maximal inhibitory concentration: 4610 nM
Compound 4: middle estimate off by 2.6-fold (0.42 log units), on the high side; low and high end bracket the measured number.
By their numbers in this assay, from the lowest: compounds 1 and 4 (each within the scatter of the next); then compounds 2 and 3 (each within the scatter of the next).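

In this assay, this place on the amide carbonyl proves sensitive to something other than the choice of halogen: the ring nitrogen of the 6-chloropyridin-3-yl group, with the chlorine kept, gives a 2.4-fold lower number from compound 2 to compound 4 (0.38 log units; beyond the scatter) when it replaces 4-chlorophenyl, and the change from 4-bromophenyl gives a 3.0-fold lower number from compound 3 to compound 4 (0.48 log units; beyond the scatter) on the same scale. With a 2.0-fold higher number from compound 1 to compound 4 (0.30 log units; within the scatter) as the remaining step, compound 4 cannot be told apart from compound 1, so a chlorine on this ring does not by itself tie a compound to the higher numbers of compound 2 and compound 3. Nothing measured here speaks to the reason for this shift.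

Still open, as far as these compounds go, is what the same nitrogen-containing ring would give with an amine or a methyl in place of the chlorine. A ring with no substituent at all at this place also remains untested among the compounds shown.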